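The source may hold more compounds than are shown below. What is called first, only, known or untested is meant among the compounds shown, and "the series" means these compounds.

Compound 1, `Nc1ccc2cccc(OC3CCCCC3)c2n1`, carries a cyclohexyl group on an oxygen on an aromatic ring. In an assay on cells with melanin-concentrating hormone receptor 1 (Homo sapiens) as the target, read by radioligand binding (a higher number here means a weaker inhibitor, a lower number a stronger inhibitor), compound 1 gives 361 nM. Compound 2, `CC(C)OCCOc1cccc2ccc(N)nc12`, replaces that cyclohexyl with a 2-isopropoxyethyl chain, and the result is an at least 5.5-fold higher number from compound 1 to compound 2 (0.74 log units; beyond the scatter). In this assay compound 2 gives > 2000 nM, which is a limit of the assay rather than a number. Compound 3, `COCCOCCOc1cccc2ccc(N)nc12`, carries a 2-methoxyethyl in place of the isopropyl on the chain. In this assay compound 3 gives > 2000 nM, again a limit. The step that the two limits leave unreadable from compound 2 to compound 3 therefore cannot be read, in keeping with the limit of > 2000 nM in this assay, at which 2 of the 3 values shown sit.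

Compound 4, `CCCC(C)Oc1cccc2ccc(N)nc12`, is the next structure. 1-methylbutyl in place of 2-isopropoxyethyl on an oxygen on an aromatic ring The change removes the ether oxygen from the side chain and leaves a branched all-carbon group, which in that respect resembles the cyclohexyl of compound 1 more than the ether chain of compound 2. Going by the values given here, the only readable step, from compound 1 to compound 2, shows that replacing the all-carbon ring with an ether chain weakened binding; compound 3 adds no readable step. The expected direction for compound 4 is therefore toward stronger binding, with a step estimated as an at least 2.8-fold lower number from compound 2 to compound 4 (0.45 log units; beyond the scatter). Compound 4 is estimated at 700 nM, within a range from 250 nM to 2000 nM.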

Compound 4, half-maximal inhibitory concentration: 105 nM
Compound 4: the middle estimate sits 6.7-fold (0.82 log units) above what was measured; the whole stated range lies above it.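

This position on the oxygen does not need a ring for good binding. In this assay, 1-methylbutyl in place of 2-isopropoxyethyl gives an at least 19-fold lower number from compound 2 to compound 4 (1.27 log units; beyond the scatter), while 1-methylbutyl in place of cyclohexyl gives a 3.4-fold lower number from compound 1 to compound 4 (0.54 log units; beyond the scatter), so an open all-carbon chain can do better here than the ring, and the loss seen with the ether chains cannot be put down simply to the missing ring. Compound 2 gives only a limit, so the first of these steps is a bound and not an exact size: the limit of > 2000 nM in this assay, at which 2 of the 4 values shown sit.

The 2-isopropoxyethyl and 1-methylbutyl groups differ in more than the ether oxygen, since their heavy-atom counts and chain shapes also differ, so the compounds shown cannot say how much of the gain belongs to removing that oxygen alone. They also leave open how binding would respond to a straight pentyl chain, a shorter ethyl group, or a chain ending in an amine or a carboxylic acid at this same place.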